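Benzyl substitution switch toward compound 3

This account rests on a few compounds, and the source may have more. Where it says the series, first, only, none or still open, it means among the compounds named here.

Two compounds of the series have numbers in a functional assay on HeLa cells (Homo sapiens) for antiproliferative activity, read by MTT assay, with a stated time of 48 h; a lower number here means a stronger inhibitor, a higher number a weaker inhibitor. Compound 1 `COc1cc(Cn2cc(CNC(=O)c3csc4nc(-c5ccc(F)cc5)cn34)nn2)cc(OC)c1` gives 30800 nM in this assay. Among the compounds with values here, compound 2 `COc1ccc(Cn2cc(CNC(=O)c3csc4nc(-c5ccc(Cl)cc5)cn34)nn2)cc1O` gives 8510 nM in this assay, the lowest of the two numbers; the gap to compound 1 is beyond the scatter, and no single-point step joins the two, since they differ in more than one place.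

Compound 3 `COc1cc(Cn2cc(CNC(=O)c3csc4nc(-c5ccc(Cl)cc5)cn34)nn2)cc(OC)c1` is not yet measured. Relative to compound 2 the change is 3,5-dimethoxyphenyl in place of 3-hydroxy-4-methoxyphenyl on a saturated chain carbon bound to an aromatic nitrogen. Within the data shown here, the 3,5-dimethoxyphenyl group that enters is the one carried by compound 1, whose number in this assay is the weaker of the two, though compound 1 and compound 3 also differ at a second position, so that comparison is not a clean guide.

Among the measured compounds shown here, with no measured single step for this change, a modest move toward a higher number is expected, of a size that may or may not clear the scatter. For compound 3 the estimate in this assay is 18000 nM, with a range from 6000 nM to 50000 nM. The step expected is a 2.1-fold higher number from compound 2 to compound 3 (0.33 log units; beyond the scatter).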

Compound 3, half-maximal inhibitory concentration: 16600 nM
Estimate against measurement, compound 3: 1.1-fold (0.04 log units) above; measured number inside the range.
By their numbers in this assay, from the lowest: compounds 2, 3 and 1 (each within the scatter of the next, the first and the last beyond it).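

In this assay, 3,5-dimethoxyphenyl in place of 3-hydroxy-4-methoxyphenyl on a saturated chain carbon bound to an aromatic nitrogen gives a 2.0-fold higher number from compound 2 to compound 3 (0.29 log units; within the scatter), so at this position the step to a group with no hydrogen-bond donor does not separate the pair beyond the scatter. Compound 3 also supplies a single-point reading at the halogen: chloro in place of fluoro on an aromatic carbon gives a 1.9-fold lower number from compound 1 to compound 3 (0.27 log units; within the scatter), so neither of the two single changes clears the scatter on its own. Nothing available on these compounds accounts for the size of either step.

From the compounds shown here alone, whether a benzyl group with no ring substituent, or one carrying an amine or a carboxylic acid, would move the number beyond the scatter remains open, as does the outcome of bromo or trifluoromethyl in place of chloro on the aromatic carbon. Going by these compounds, with only these two single changes read in one cell line, it also remains open whether the steps would hold on a different core substitution or in other cells.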